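The source may report more compounds than this note shows. Statements on the series, on what has been measured and on what is new or still open speak of the compounds shown alone.

Working notes on the thiazolyl ketone series.

Compound 3 `COc1ccc(-c2nc(SCC(=O)c3sc(-c4ccc(Cl)cc4)nc3C)[nH]c(=O)c2C#N)cc1OC` gives 83.3% in a functional assay on U-87MG ATCC cells for antiproliferative activity against U-87 MG (Homo sapiens), read by MTT assay, with a stated time of 48 h, tested at 10 uM (on this read-out higher numbers stand for a weaker effect at the one concentration tested and lower numbers for a stronger effect), the highest of the three numbers measured. Compound 2 `COc1ccc(-c2nc(SCC(=O)c3sc(-c4ccccc4)nc3C)[nH]c(=O)c2C#N)cc1OC` gives 69.8% in this assay, and compound 1 `Cc1nc(-c2ccc(Cl)cc2)sc1C(=O)CSc1nc(N)c(C#N)c(-c2ccc(Cl)cc2)n1` gives 37.3% in this assay. Going by the values given here, the one single-point step in the set is a number 13.5 percentage points higher from compound 2 to compound 3 (beyond the scatter). Compound 1 differs from the other two in more than one place, so its value stands alone.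

Compound 4 `COc1cccc(-c2nc(SCC(=O)c3sc(-c4ccc(Cl)cc4)nc3C)[nH]c(=O)c2C#N)c1` is the next member and differs from compound 3 by hydrogen in place of methoxy on an aromatic carbon. Among the compounds with values here, no measured step involves the loss of a methoxy group, so nothing in the set speaks directly to this change; the only step known, a number 13.5 percentage points higher from compound 2 to compound 3 (beyond the scatter), concerns a different group. A move of limited size is therefore expected, with a slight lean towards a lower number, since the 3,4-dimethoxyphenyl group is present in the highest compound measured. The expected step is a number 7.3 percentage points lower from compound 3 to compound 4 (within the scatter). Compound 4 is estimated at 76% in this assay, between 58% and 94%.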

Compound 4, a percentage reported as activity, at one concentration (the size of the read-out at that concentration, not a potency): 89.7%
Compound 4: middle estimate off by 13.7 percentage points, on the low side; the measured number falls inside the stated range.
By their numbers in this assay, from the lowest: compound 1; then compound 2; then compounds 3 and 4 (each within the scatter of the next).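

In this assay, hydrogen in place of methoxy, the change from 3,4-dimethoxyphenyl to 3-methoxyphenyl, gives a number 6.4 percentage points higher from compound 3 to compound 4 (within the scatter). Going by these compounds alone, this is the first step read on this aromatic ring, and it shows that at this position, ortho to a methoxy group and para to a large group, the two compounds cannot be told apart on this read-out, so the read-out does not depend on this methoxy group. The data give no reason for this result.

Going by these compounds, it remains open whether the methoxy group kept in compound 4 can also be replaced by hydrogen, and whether an amine or a hydroxyl group at the vacated position would move the number beyond the scatter. Compound 1, at 37.3%, is still linked to the others by no single change.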